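Cyclopropyl Amide Variant of a Diazabicyclic Nicotinic Ligand

A few compounds are considered here, and "the series" means these few. Any claim that something is new, unique, unknown or untested is made for them only; others in the source may bear on it.

Compound 2 `CC(C)C(=O)N1CC2CC(C1)N2` gives 580 nM in an assay on CHO cells for displacement of a labelled ligand from Neuronal acetylcholine receptor; alpha3/alpha6/beta2/beta3 (Homo sapiens), read by scintillation counting (a lower number here means a stronger inhibitor, a higher number a weaker inhibitor), the second highest of three numbers. Compound 1 `CCC(=O)N1CC2CC(C1)N2` gives 190 nM, and compound 3 `O=C(C1CC=CC1)N1CC2CC(C1)N2` gives 1100 nM; the gap between compound 2 and compound 3 lies within the scatter, while the step of a 3.1-fold higher number from compound 1 to compound 2 (0.48 log units; beyond the scatter) lies beyond it. Compound 4 `C[C@@H]1C[C@H]1C(=O)N1CC2CC(C1)N2` carries 2-methylcyclopropyl in place of isopropyl on a carbonyl carbon. Among the compounds with values here, only one measured step bears on this change, a 3.1-fold higher number from compound 1 to compound 2 (0.48 log units; beyond the scatter), a modest weakening on branching the acyl chain; the entering group brings more heavy atoms and a ring to the same carbonyl carbon. The expected step is therefore small and, if anything, toward a higher number, a 1.3-fold higher number from compound 2 to compound 4 (0.11 log units; within the scatter). Compound 4 is estimated at 750 nM in this assay, between 300 nM and 1900 nM.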

Compound 4, inhibition constant: 14 nM
Estimate against measurement, compound 4: 54-fold (1.73 log units) above; the measured number lies below the stated range.
By their numbers in this assay, from the lowest: compound 4; then compound 1; then compounds 2 and 3 (each within the scatter of the next).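

Within the data shown here, at the carbonyl carbon, the earlier compounds showed only a modest weakening on branching, yet 2-methylcyclopropyl in place of isopropyl gives a large gain in this assay (a 41-fold lower number from compound 2 to compound 4 (1.62 log units; beyond the scatter)). In place of ethyl, the same group gives a 14-fold lower number from compound 1 to compound 4 (1.13 log units; beyond the scatter), so a larger acyl group at this position need not weaken binding. Nothing measured here accounts for this gain.

The compounds shown leave open whether the gain comes from the ring or its methyl, which a plain cyclopropyl group would help separate. The contribution of the two defined stereocentres also remains unresolved.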